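Swapping a hydroxy for a methyl on the phenyl ring

The compounds below may be only part of what the source reports. "The series", "measured", "known", "first", "only" and "open" are said of these compounds alone.

Two members of this series share one core, differing only in the ring attached to it. Compound 1, `N#Cc1c(-c2ccc(O)cc2)c(C#N)c(=O)n(/N=C/c2cn(-c3ccccc3)nc2-c2ccccc2)c1N`, carries a 4-hydroxyphenyl there; in an ADME assay on NIH3T3 cells (Mus musculus) for cytotoxicity, read by MTT assay (on this read-out higher numbers stand for weaker inhibition and lower numbers for stronger inhibition), compound 1 gives 110 ug/mL, the highest of the two numbers seen so far. Compound 2, `N#Cc1c(-c2cccc(Cl)c2)c(C#N)c(=O)n(/N=C/c2cn(-c3ccccc3)nc2-c2ccccc2)c1N`, has a 3-chlorophenyl in its place, and in this assay compound 2 gives 52 ug/mL, so the step of a 2.1-fold lower number from compound 1 to compound 2 (0.33 log units; beyond the scatter).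

Compound 3, `Cc1ccc(-c2c(C#N)c(N)n(/N=C/c3cn(-c4ccccc4)nc3-c3ccccc3)c(=O)c2C#N)cc1`, has not yet been measured in this assay. It differs from compound 1 by methyl in place of hydroxy on an aromatic carbon.

Among the compounds with values here, only the step from compound 1 to compound 2 bears on this change, and only loosely, since it alters the ring at a different place and with a different group. Within the data shown here, it suggests that moving away from the hydroxy can lower the number somewhat, so a modest fall is expected, although no step within the scatter can be ruled out. The value of compound 3 is estimated at 75 ug/mL, within 35 ug/mL to 160 ug/mL, a step of a 1.5-fold lower number from compound 1 to compound 3 (0.17 log units; within the scatter).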

Compound 3, half-maximal inhibitory concentration: 98 ug/mL
Estimate against measurement, compound 3: 1.3-fold (0.12 log units) below, within the range that was stated.
By their numbers in this assay, from the lowest: compounds 2, 3 and 1 (each within the scatter of the next, the first and the last beyond it).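

In this assay, putting a methyl where the hydroxy stood gives a 1.1-fold lower number from compound 1 to compound 3 (0.05 log units; within the scatter), so at this place on the phenyl ring, losing a group with a hydrogen-bond donor and acceptor for one with neither produces no readable change. The other new comparison, a 1.9-fold higher number from compound 2 to compound 3 (0.28 log units; within the scatter), also stays within the scatter, so compound 3 cannot be told apart from either compound 1 or compound 2, even though those two can be told apart from each other. Nothing available here accounts for this result.

On these data alone, it remains open whether an amine or a carboxylic acid at this place would shift the number beyond the scatter. A 4-chlorophenyl would also help, since the step between the 3-chlorophenyl and the 4-methylphenyl changes both the group and where it sits.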